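The compounds below may be only part of what the source reports. "The series", "measured", "known", "first", "only" and "open" are said of these compounds alone.

Three compounds with a shared core were tested in an assay on CHO cells for agonist activity at 5-hydroxytryptamine receptor 1D (Homo sapiens), read by GTPgammaS binding; on this read-out lower numbers stand for an effect already at smaller amounts and higher numbers for an effect only at larger amounts of compound. Compound 1 `OC[C@H](NC1CCN(CCCc2c[nH]c3ccc(-n4ccnc4)cc23)CC1)c1ccccc1` gives 0.8 nM. Among the measured compounds shown here, compound 2 `CN(Cc1cccs1)C1CCN(CCCc2c[nH]c3ccc(-n4cnnc4)cc23)CC1` gives 3.5 nM, and compound 3 `C[C@@H](NC1CCN(CCCc2c[nH]c3ccc(-n4cnnc4)cc23)CC1)c1ccccc1` gives 13 nM, the highest number of the three; the only step that reaches it, a 3.7-fold higher number from compound 2 to compound 3 (0.57 log units; beyond the scatter), concerns the amine on a saturated ring carbon. Compound 4 `C[C@@H](NC1CCN(CCCc2c[nH]c3ccc(-n4ccnc4)cc23)CC1)c1ccccc1` differs from compound 3 in one place: 1H-imidazol-1-yl in place of 4H-1,2,4-triazol-4-yl on an aromatic carbon. For the measured compounds named here, no measured step changes this ring alone; compound 1, which also carries the 1H-imidazol-1-yl group but a different amine, stands far lower than compound 3. A step toward lower numbers is therefore expected, a 3.3-fold lower number from compound 3 to compound 4 (0.51 log units; beyond the scatter), with wide uncertainty. Compound 4 is estimated at 4 nM, between 1 nM and 15 nM.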

Compound 4, half-maximal effective concentration: 6.2 nM
Compound 4: middle estimate off by 1.6-fold (0.19 log units), on the low side; low and high end bracket the measured number.
By their numbers in this assay, from the lowest: compound 1; then compounds 2 and 4 (each within the scatter of the next); then compound 3.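

Among the compounds shown here, with the amine held constant in this assay, putting 1H-imidazol-1-yl in place of 4H-1,2,4-triazol-4-yl on the aromatic carbon gives a 2.1-fold lower number from compound 3 to compound 4 (0.32 log units; beyond the scatter) as the first direct reading of this ring change. With 1H-imidazol-1-yl held constant, 1-phenylethyl in place of 2-hydroxy-1-phenylethyl on the amine nitrogen gives a 7.8-fold higher number from compound 1 to compound 4 (0.89 log units; beyond the scatter) as a separate reading of the amine side. Nothing measured here explains either step.

On these data alone, whether the ring change reads the same with the methyl((thiophen-2-yl)methyl)amino group of compound 2 remains open. So does the effect of a 1H-pyrazol-1-yl ring on that aromatic carbon, or of a methoxy group in place of the hydroxyl.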